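Changing the aniline ring on a quinazoline cytotoxicity series

The source may report more compounds than this note shows. Statements on the series, on what has been measured and on what is new or still open speak of the compounds shown alone.

In a functional assay on SK-HEP1 cells (Homo sapiens) for cytotoxicity, read by MTT assay, with a stated time of 48 h (on this read-out higher numbers stand for weaker inhibition and lower numbers for stronger inhibition), compound 2, with structure `COc1cc2nc(Cl)nc(Nc3cccc(Cl)c3)c2cc1OC`, gives 16500 nM. Compound 1, with structure `C#Cc1cccc(N(C)c2nc(Cl)nc3cc(OC)c(OC)cc23)c1`, gives 12300 nM in this assay, and these two numbers lie within the usual scatter of each other, so neither can be called more or less active. Compound 3, with structure `COc1cc2nc(Cl)nc(Nc3cccc(O)c3)c2cc1OC`, gives only a limit of the assay in this assay, > 40000 nM. For the measured compounds named here, the one step measured between two compounds that differ in a single place, an at least 2.4-fold higher number from compound 2 to compound 3 (0.38 log units; beyond the scatter), places hydroxy where chloro stood and is read against (the limit of > 40000 nM in this assay, at which 1 of the 3 values shown sits).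

Compound 4, with structure `COc1cc2nc(Cl)nc(Nc3cc(C)ccc3F)c2cc1OC`, has not yet been measured. It differs from compound 2 in this way: 2-fluoro-5-methylphenyl in place of 3-chlorophenyl on a nitrogen on an aromatic ring. Going by the values given here, no measured step swaps one substituted phenyl ring for another of this kind, so the hydroxy-for-chloro step offers only indirect guidance; it shows that altering this ring can shift the number, but in that case a donor group entered, which is not the case here.

The expectation is therefore no step beyond the scatter, a 1.0-fold lower number from compound 2 to compound 4 (0.01 log units; within the scatter). Compound 4 is estimated at 16000 nM in this assay, within a range from 6000 nM to 40000 nM.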

Compound 4, half-maximal inhibitory concentration: > 40000 nM
Compound 4 gave a limit, no number; the forecaster's own chance of this, stated with the estimate: 20%; middle value at least 2.5-fold (0.39 log units) from the limit.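

In this assay, putting 2-fluoro-5-methylphenyl in place of 3-chlorophenyl on the nitrogen gives an at least 2.4-fold higher number from compound 2 to compound 4 (0.38 log units; beyond the scatter). The earlier step, an at least 2.4-fold higher number from compound 2 to compound 3 (0.38 log units; beyond the scatter), brought in a hydroxy group, whereas neither ring in the new step carries a hydrogen-bond donor, so a weaker result at this position does not require a donor to enter. The step from compound 3 to compound 4 cannot be read, and the true size of each rise stays unknown, as compound 3 and compound 4 both end at a limit of the assay: the limit of > 40000 nM in this assay, at which 2 of the 4 values shown sit.

The new step changes several features of the ring at once: chloro leaves while fluoro and methyl enter, so the compounds shown cannot say which of these changes matters, or whether it takes them together. Also open, on these data alone, is how this position would respond to a ring bearing an amine or a carboxylic acid, and whether any ring here could give a clearly lower number than compound 2.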